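The source may report more compounds than this note shows. Statements on the series, on what has been measured and on what is new or still open speak of the compounds shown alone.

The shared core is that of compound 1 `NC(=O)[C@@H]1CCC(=O)N1Cc1ccc(-c2ccccc2)cc1`, and in an assay on isolated protein for inhibition of matrix metalloproteinase-9 (Homo sapiens), read by fluorescence, with stated times of 1 h and 30 min (a higher number here means a weaker inhibitor, a lower number a stronger inhibitor), compound 1 gives "not determined" (no result reported). Compound 2 `O=C(NO)[C@@H]1CSCN1S(=O)(=O)c1ccc(-c2ccccc2)cc1` carries the hydroxamic acid on the same ring system with a sulfonyl-linked biphenyl, and in this assay compound 2 gives 230 nM. Among the measured compounds shown here, compound 3 `COc1ccc(Oc2ccc(S(=O)(=O)N3CSC[C@H]3C(=O)NO)cc2)cc1` has 4-methoxyphenoxy in place of phenyl on an aromatic carbon; in this assay compound 3 gives 2 nM, the lowest of the two numbers at hand, its only neighbour being compound 2, with the step of a 120-fold lower number from compound 2 to compound 3 (2.06 log units; beyond the scatter). Compound 4 `O=C(NO)[C@@H]1CSCN1S(=O)(=O)c1ccc(Oc2ccc(Cl)cc2)cc1` differs from compound 3 by chloro in place of methoxy on an aromatic carbon. For the measured compounds named here, no measured step touches this position: the single step available exchanged the whole outer group and gives no guide to swapping methoxy for chloro at its far end. On that footing no change beyond the scatter is expected in this assay, in either direction. Compound 4 is therefore expected at 3 nM, with a range from 1 nM to 10 nM. The expected step is a 1.5-fold higher number from compound 3 to compound 4 (0.18 log units; within the scatter).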

Compound 4, half-maximal inhibitory concentration: 16 nM
For compound 4 the middle estimate is 5.3-fold (0.73 log units) below the measured one; measured number above the stated range.
By their numbers in this assay, from the lowest: compound 3; then compound 4; then compound 2.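

In this assay the far end of the outer group proves to be a position that responds, with chloro in place of methoxy on the aromatic carbon giving a modest step beyond the scatter (an 8.0-fold higher number from compound 3 to compound 4 (0.90 log units; beyond the scatter)). The change from phenyl to 4-chlorophenoxy still gives a large step (a 14-fold lower number from compound 2 to compound 4 (1.16 log units; beyond the scatter)), so the lower number relative to compound 2 does not depend on the methoxy group alone. Nothing at hand accounts for the difference between methoxy and chloro.

Open, as far as these compounds go, is how an amine, a carboxylic acid or a longer alkoxy chain at this position would compare with methoxy and chloro. Also open, from the compounds shown here alone, is whether the exchange of methoxy for chloro gives a step of this size on any other core.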